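The compounds below may be only part of what the source reports. "The series", "measured", "known", "first", "only" and "open" are said of these compounds alone.

Measured compounds:
- Compound 1 `COc1ccc(CNc2nc3cc(N)cc(N)c3nc2-c2ccccc2)cc1OC`: 53700 nM
- Compound 2 `COc1cc(CNc2nc3cc(N)cc(N)c3nc2-c2ccccc2)cc(OC)c1OC`: 31600 nM
- Compound 3 `CCOC(=O)[C@H](CCC(=O)O)NC(=O)c1ccc(Oc2nc3cc(N)cc(N)c3nc2-c2ccccc2)cc1`: 31600 nM

In a functional assay on CAKI-1 cells (Homo sapiens) for inhibition, read by sulforhodamine B assay, with a stated time of 48 h (a higher number here means that more compound is tolerated, a lower number that less compound is tolerated), compound 1 stands at 53700 nM. Compound 2 gives 31600 nM and compound 3 gives 31600 nM; both of these lie within the usual scatter of the number for compound 1, so none of the three compounds is set apart from the others in this assay.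

Compound 4 `COc1ccc(CNc2nc3cc(N)cc(N)c3nc2-c2ccccc2)cc1` has not yet been measured. It differs from compound 1 in one place: hydrogen in place of methoxy on an aromatic carbon. Among the compounds with values here, the only measured step that touches this part of the molecule is a 1.7-fold lower number from compound 1 to compound 2 (0.23 log units; within the scatter), where a methoxy group was added to the same ring and the number hardly moved. Taking a methoxy group away from the ring, as happens from compound 1 to compound 4, is the opposite kind of change, and the one comparison available suggests that such changes on this ring do not move the number beyond the scatter.

On that basis the step of a 1.1-fold lower number from compound 1 to compound 4 (0.03 log units; within the scatter) is expected to be small. For compound 4 the estimate in this assay is 50000 nM, with a likely range from 20000 nM to 130000 nM.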

Compound 4, concentration lethal to 50% of the cells: 79400 nM
Estimate against measurement, compound 4: 1.6-fold (0.20 log units) below; measured number inside the range.
By their numbers in this assay, from the lowest: compounds 2, 3, 1 and 4 (each within the scatter of the next, the first and the last beyond it).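

In this assay, replacing 3,4-dimethoxyphenyl with 4-methoxyphenyl, which puts hydrogen in place of a methoxy group, gives a 1.5-fold higher number from compound 1 to compound 4 (0.17 log units; within the scatter). The earlier compounds shown here offered only the addition of a methoxy group to this ring, a 1.7-fold lower number from compound 1 to compound 2 (0.23 log units; within the scatter), whereas this new step shows that taking one away also stays within the scatter, so in this small set neither direction of change separates the compounds. No independent measurement here explains why the methoxy group at this place makes so little difference to the number.

The compounds shown carry only hydrogen or methoxy at this place, so it remains open whether an amine, a carboxylic acid or a longer chain such as butoxy on the same aromatic carbon would move the number beyond the scatter. From the compounds shown here alone, it is also open whether the same tolerance would hold once the last methoxy group on this ring is replaced by hydrogen, or whether that remaining group matters more than the one replaced here.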